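This account rests on a few compounds, and the source may have more. Where it says the series, first, only, none or still open, it means among the compounds named here.

Compound 1 `Cc1cn([C@@H]2O[C@H](CO[Si](C)(C)C(C)(C)C)[C@@]3(OS(=O)(=O)C=C3NC(=O)NC(=O)c3ccccc3)[C@H]2O[Si](C)(C)C(C)(C)C)c(=O)n(C)c1=O` is tested in an ADME assay on HEL cells (Homo sapiens) for cytotoxicity, with a stated time of 3 days; on this read-out lower numbers stand for higher toxicity in this test and higher numbers for lower toxicity in this test. There, compound 1 gives > 200000 nM, which is a limit of the assay and not a number. Two close relatives give some context. Compound 2 `Cc1cn([C@@H]2O[C@H](CO[Si](C)(C)C(C)(C)C)[C@@]3(OS(=O)(=O)C=C3NC(=O)NC(=O)c3ccccc3)[C@H]2O[Si](C)(C)C(C)(C)C(C)C)c(=O)n(C)c1=O` gives >= 100000 nM, which is also a limit. Compound 3 `Cc1cn([C@@H]2O[C@H](COC(=O)c3ccccc3)[C@@]3(OS(=O)(=O)C=C3NC(=O)NC(=O)c3ccccc3)[C@H]2O[Si](C)(C)C(C)(C)C)c(=O)n(C)c1=O` gives 100000 nM, a measured number.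

The change to isopropyl on the silicon-bearing side chain is a step that the two limits leave unreadable from compound 1 to compound 2. Exchanging the group on the oxygen of a saturated carbon is an at least 2.0-fold lower number from compound 1 to compound 3 (0.30 log units; that floor lies within the scatter). Both relatives keep the benzoyl group, so neither step measures directly what happens when it is removed.

That removal defines compound 4 `Cc1cn([C@@H]2O[C@H](CO[Si](C)(C)C(C)(C)C)[C@@]3(OS(=O)(=O)C=C3NC(N)=O)[C@H]2O[Si](C)(C)C(C)(C)C)c(=O)n(C)c1=O`. The difference is hydrogen in place of benzoyl on an amide-type nitrogen, which turns (benzoylcarbamoyl)amino into ureido.

Within the data shown here, with no direct precedent, the expectation rests on how high the numbers stay across the family, with compound 3 at 100000 nM as the only true number. In this assay, a modest move toward a lower number is therefore expected, and the expected change is an at least 1.6-fold lower number from compound 1 to compound 4 (0.22 log units; that floor lies within the scatter). For compound 4 the estimate is 120000 nM, with an expected range from 40000 nM to 250000 nM.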

Compound 4, half-maximal cytotoxic concentration: 11000 nM
The estimate for compound 4 lay 11-fold (1.04 log units) above the measured number; measured number outside the range, below it.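

In this assay, putting hydrogen in place of benzoyl on the amide-type nitrogen, which turns (benzoylcarbamoyl)amino into ureido, gives an at least 18-fold lower number from compound 1 to compound 4 (1.25 log units; beyond the scatter). Among these compounds, a lower number here stands for higher toxicity in this test, so what sits on this nitrogen clearly matters for the read-out, something the earlier steps could not show: they changed other places, kept the benzoyl group, and gave no step that can be read as lying beyond the usual scatter. The printed step is a floor and not an exact size, because compound 1 stands at a limit of the assay: the limit of > 200000 nM in this assay, at which 1 of the 4 values shown sits.

From the compounds shown here alone, with only hydrogen and benzoyl compared at this nitrogen, it remains open whether the higher number of compound 1 depends on the aromatic ring of the benzoyl group or on its carbonyl, and an acetyl group in the same place would help to separate the two. Going by these compounds, it is also open whether the same exchange would have a similar effect on compound 3, which carries a different group on the oxygen of the saturated carbon.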